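This account rests on a few compounds, and the source may have more. Where it says the series, first, only, none or still open, it means among the compounds named here.

In an ADME assay on microsomes from liver (Homo sapiens) for metabolic stability, read by mass spectrometry, using NADPH, tested at 1.5 uM (on this read-out higher numbers stand for a longer-lived compound and lower numbers for a shorter-lived compound), compound 1 `O=C(Nc1ccc2sc(-c3ccccc3)nc2c1)N1CCCCC1` gives > 1 h, which is a limit of the assay and not a number. Compound 2 `O=C(Nc1ccc2sc(-c3ccc(F)c(F)c3)nc2c1)N1CCCC1` gives > 1 h, also only a limit, so its position is known no more closely than that. Compound 3 `O=C(Nc1ccc2sc(-c3cccc(F)c3)nc2c1)N1CCCC1` differs from compound 2 by hydrogen in place of fluoro on an aromatic carbon, turning 3,4-difluorophenyl into 3-fluorophenyl. Among the compounds with values here, no measured pair shows this change. The expected step in this assay, a step that the limit leaves unreadable from compound 2 to compound 3, stays within the scatter, with no direction expected. The estimate for compound 3 is 1.5 h, with an expected range of 0.8 h to 3 h.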

Compound 3, half-life: 0.617 h
Beside the measured number, compound 3's estimate is 2.4-fold (0.39 log units) above it; the whole stated range lies above it.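

In this assay, within the data shown here, compound 3 gives the first true number, so hydrogen in place of fluoro, para to a large group and ortho to a fluoro group, now has a direction (an at least 1.6-fold lower number from compound 2 to compound 3 (0.20 log units; that floor lies within the scatter)). Turning 3,4-difluorophenyl into 3-fluorophenyl is thus not shown to be neutral, although the step may be no larger than the scatter. Only a floor can be read because compound 2 stands at a limit: the limit of > 1 h in this assay, at which 2 of the 3 values shown sit.

From the compounds shown here alone, the true size of this step stays open. So does the effect of a chloro, methoxy or amino group in place of this fluoro.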